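A few compounds are considered here, and "the series" means these few. Any claim that something is new, unique, unknown or untested is made for them only; others in the source may bear on it.

Compound 2 `CCc1ccc(SCc2ccc(/C=C/C(=O)Nc3ccccc3N)cc2)cc1` and compound 1 `Nc1ccccc1NC(=O)/C=C/c1ccc(CSc2cccc(F)c2)cc1` share one core and differ only at the outer end of the molecule. In a functional assay on A-375 cells (Homo sapiens) for inhibition, read by CCK-8 assay, with a stated time of 72 h, tested at 8 uM (a higher number here means more inhibition of growth at the concentration tested, a lower number less inhibition of growth), compound 2 gives 58.4%, while compound 1 gives 9.08%. The change between them is 3-fluorophenyl in place of 4-ethylphenyl on a sulfur and it produced the step of a number 49.3 percentage points lower from compound 2 to compound 1 (beyond the scatter), a large drop.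

Compound 3 `CCc1ccc(SCc2ccc(C(=O)Nc3ccccc3N)cc2)cc1` carries the same 4-ethylphenyl group on a sulfur as compound 2, but on a different core; the difference between the two cores is not broken down here. In this assay compound 3 gives 71.1%, the highest of the three measured numbers.

Compound 4 `Nc1ccccc1NC(=O)c1ccc(CSc2cccc(F)c2)cc1` is the partner of compound 3 in the same way that compound 1 is the partner of compound 2: the change is 3-fluorophenyl in place of 4-ethylphenyl on a sulfur, made at the same place, on a sulfur whose other neighbour is a saturated chain carbon. Since this is the same change that gave the large drop from compound 2 to compound 1, a step of similar size is expected from compound 3 to compound 4, namely a number 47.1 percentage points lower from compound 3 to compound 4 (beyond the scatter), resting on the earlier step of a number 49.3 percentage points lower from compound 2 to compound 1 (beyond the scatter). For the measured compounds named here, the core of compound 3 is different from that of compound 2, and only one earlier example of the change exists. The expected size therefore carries wide uncertainty. Compound 4 is therefore estimated at 24% in this assay, with a range from 6% to 48%.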

Compound 4, percent growth inhibition at one concentration: 76.3%
Compound 4: middle estimate off by 52.3 percentage points, on the low side; the whole stated range lies below it.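

On the core of compound 3, the change from 4-ethylphenyl to 3-fluorophenyl on a sulfur does not repeat the large drop seen on the other core: in this assay the result is a number 5.2 percentage points higher from compound 3 to compound 4 (within the scatter), so the two compounds cannot be told apart here. The effect of this change therefore did not transfer from one core to the other, and a step measured on one core proved a poor guide to the same step on the other: the same change on two cores in this assay, a number 49.3 percentage points lower (beyond the scatter) from compound 2 to compound 1 and a number 5.2 percentage points higher (within the scatter) from compound 3 to compound 4, 54.5 percentage points apart, beyond the scatter of two such steps This does not show which structural difference between the two cores matters, or why it matters, and with one pair on each core it offers no general rule for other changes in this series.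

The compounds shown leave open how a plain phenyl group, or a phenyl ring carrying an amine or a carboxylic acid, would behave on the same sulfur on each core. Such matched pairs could show whether the gap between the two cores is peculiar to 3-fluorophenyl and 4-ethylphenyl or also appears with other groups.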